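Swapping Chlorine for Fluorine on the Benzoyl Group

This account rests on a few compounds, and the source may have more. Where it says the series, first, only, none or still open, it means among the compounds named here.

Of the compounds shown here, three built on the same core have been measured in a functional assay on DLD-1 cells (Homo sapiens); a higher number here means a weaker inhibitor, a lower number a stronger inhibitor. Compound 1 `O=S(=O)(c1ccccc1)N(Cc1c[nH]cn1)c1ccc(N2CCN(C(=S)NC3CCCCC3)CC2)cc1` gives 1000 nM in this assay. Compound 2 `N#Cc1ccc(Cn2cncc2CN(c2ccc(N3CCN(C(=O)c4ccc(Cl)s4)CC3)cc2)S(=O)(=O)c2ccccc2)cc1` gives 200 nM in this assay. Compound 3 `N#Cc1ccc(Cn2cncc2CN(C(=O)c2cccc(Cl)c2)c2ccc(N3CCN(C(=O)c4ccc(Cl)s4)CC3)cc2)cc1` gives 2 nM in this assay. For the measured compounds named here, the one measured step between neighbours is a 100-fold lower number from compound 2 to compound 3 (2.00 log units; beyond the scatter). Going by the values given here, on the numbers so far, compound 3 stands lowest of the three, with compound 2 the nearest and compound 1 the furthest away, and both gaps lie beyond the scatter.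

Compound 4 `N#Cc1ccc(Cn2cncc2CN(C(=O)c2cccc(F)c2)c2ccc(N3CCN(C(=O)c4ccc(Cl)s4)CC3)cc2)cc1` is the next member. It differs from compound 3 by fluoro in place of chloro on an aromatic carbon. Among the compounds with values here, no measured step exchanges one halogen for another; the only step on record, a 100-fold lower number from compound 2 to compound 3 (2.00 log units; beyond the scatter), replaces a whole group on the ring nitrogen and so does not bear directly on this smaller exchange. Without a closer precedent, the expectation is a step that stays within the usual scatter, with the number of compound 4 close to that of compound 3. In this assay compound 4 is therefore expected to give about 4 nM, within a range from 1.5 nM to 12 nM. The expected step is a 2.0-fold higher number from compound 3 to compound 4 (0.30 log units; within the scatter).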

Compound 4, half-maximal inhibitory concentration: 6 nM
Compound 4: the middle estimate sits 1.5-fold (0.18 log units) below what was measured; the measured number falls inside the stated range.
By their numbers in this assay, from the lowest: compound 3; then compound 4; then compound 2; then compound 1.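

For the compounds shown here, this is the first measured exchange of one halogen for another on this ring, and in this assay it gives a 3.0-fold higher number from compound 3 to compound 4 (0.48 log units; beyond the scatter) as a modest but real change, so a swap of a single heavy atom at this carbon is enough to move the number beyond the scatter. The larger gain from replacing phenylsulfonyl largely survives the swap, with a 33-fold lower number from compound 2 to compound 4 (1.52 log units; beyond the scatter) as the step for the fluoro version, so that replacement does not depend on chloro being the halogen on the ring. Nothing measured here explains why chloro and fluoro differ at this position.

Among the compounds shown, this carbonyl-linked ring carries only chloro or fluoro, so it remains open how a plain hydrogen, a methoxy group or an amine on the same carbon would compare. Also open, as far as these compounds go, is whether the chloro-to-fluoro exchange would give a step of similar size in a compound that keeps the phenylsulfonyl group on the nitrogen.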